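A few compounds are considered here, and "the series" means these few. Any claim that something is new, unique, unknown or untested is made for them only; others in the source may bear on it.

Compound 1 `COc1ccc2c(c1)c(C=O)cn2Cc1cn([C@@H]2O[C@H](COC(C)=O)[C@@H](OC(C)=O)[C@H](OC(C)=O)[C@H]2OC(C)=O)nn1` is an indole-derived glycoside bearing a formyl group on the shared core. In a functional assay on MCF7 cells (Homo sapiens) for cytotoxicity, read by sulforhodamine B assay, with a stated time of 48 h (a lower number here means a stronger inhibitor, a higher number a weaker inhibitor), compound 1 gives only a limit, > 200000 nM, so its potency is not pinned to a number; it stands at the limit of > 200000 nM in this assay, at which 1 of the 2 values shown sits, the weak end of what is shown. Compound 2 `CC(=O)OC[C@H]1O[C@@H](n2cc(Cn3cc(/C=C/C(=O)c4cccnc4)c4ccccc43)nn2)[C@H](OC(C)=O)[C@@H](OC(C)=O)[C@@H]1OC(C)=O`, a related glycoside with a different core and an enone side chain, gives 22300 nM in this assay.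

Compound 3 `COc1ccc2c(c1)c(/C=C1/C(=O)Nc3ccc(F)cc31)cn2Cc1cn([C@@H]2O[C@H](COC(C)=O)[C@@H](OC(C)=O)[C@H](OC(C)=O)[C@H]2OC(C)=O)nn1` differs from compound 1 in one place: a group of 12 heavy atoms (9 carbon, 1 nitrogen, 1 oxygen, 1 fluorine; one five-membered non-aromatic ring with 1 hetero atom, one six-membered aromatic ring of carbon only) in place of a group of 2 heavy atoms (1 carbon, 1 oxygen; no ring), on an aromatic carbon, where the large group carries a hydrogen-bond donor and acceptor that the formyl group lacks. Because compound 1 sits at the limit of > 200000 nM in this assay, at which 1 of the 2 values shown sits, any measurable value for compound 3 would mean a step toward stronger inhibition. The change is expected to bring compound 3 into the measurable range, with the step from compound 1 to compound 3 estimated at an at least 10-fold lower number from compound 1 to compound 3 (1.00 log units; beyond the scatter), beyond the scatter. Compound 3 is expected to give about 20000 nM, plausibly between 3000 nM and 200000 nM.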

Compound 3, half-maximal inhibitory concentration: > 200000 nM
Compound 3 was reported as a limit (the forecaster's own chance of this, stated with the estimate: 30%); middle value at least 10-fold (1.00 log units) from the limit.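

Compound 3, like compound 1, is reported in this assay only as a limit, so no step between compound 1 and compound 3 can be read: the limit of > 200000 nM in this assay, at which 2 of the 3 values shown sit.

The compounds shown leave open whether the group that enters in place of formyl changes potency at all, and in which direction.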